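The compounds below may be only part of what the source reports. "The series", "measured", "known", "first", "only" and "open" are said of these compounds alone.

Compound 2 `O/N=C(\CCN1CCN(c2ccccn2)CC1)c1cccc(F)c1` carries the highest number of the two compounds measured in a functional assay on HEK293 cells with D(4) dopamine receptor (Homo sapiens) as the target, read by FLIPR; on this read-out lower numbers stand for an effect already at smaller amounts and higher numbers for an effect only at larger amounts of compound: compound 2 gives 17.1 nM, whereas compound 1 `Cc1ccccc1/C(CCN1CCN(c2ccccn2)CC1)=N/O` gives 4.2 nM, and the step between them, a 4.1-fold higher number from compound 1 to compound 2 (0.61 log units; beyond the scatter), replaces the ring substituent on the carbon bearing the double bond to nitrogen. Compound 3 `O/N=C(\CCN1CCN(c2ccccn2)CC1)c1cccc(Cl)c1` differs from compound 2 by chloro in place of fluoro on an aromatic carbon. Going by the values given here, no measured step covers this exchange of one halogen for another; the only step available, a 4.1-fold higher number from compound 1 to compound 2 (0.61 log units; beyond the scatter), concerns a different pair of substituents and bears on the question only loosely, showing that changes at this aromatic ring can move the read-out by a modest amount. Because the step of a 4.1-fold higher number from compound 1 to compound 2 (0.61 log units; beyond the scatter) is modest and the present change is smaller, compound 3 is expected to stay close to compound 2, with no step beyond the scatter. The expected step is a 1.1-fold lower number from compound 2 to compound 3 (0.06 log units; within the scatter). Compound 3 is therefore estimated at 15 nM, in a range from 5 nM to 45 nM.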

Compound 3, half-maximal effective concentration: 11.9 nM
Compound 3: the middle estimate sits 1.3-fold (0.10 log units) above what was measured, and the stated range covers the measured number.
By their numbers in this assay, from the lowest: compound 1; then compounds 3 and 2 (each within the scatter of the next).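

In this assay, chloro in place of fluoro on this aromatic carbon, meta to a large group, leaves the read-out within the scatter (a 1.4-fold lower number from compound 2 to compound 3 (0.16 log units; within the scatter)), so this exchange of one halogen for another does not separate compound 2 from compound 3. The gap to the 2-methylphenyl of compound 1 persists with the new halogen (a 2.8-fold higher number from compound 1 to compound 3 (0.45 log units; beyond the scatter)), and compound 1 now has the lowest number, beyond the scatter from both 3-halogen compounds. Nothing available explains these numbers.

The compounds shown leave open whether that gap follows from the group itself or from its place on the ring, as none carries 3-methylphenyl or 2-chlorophenyl. Going by these compounds, it also remains open how methoxy, nitrile or trifluoromethyl in this place would read.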